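The source may report more compounds than this note shows. Statements on the series, on what has been measured and on what is new or still open speak of the compounds shown alone.

Of the compounds shown here, three built on one shared core have been measured in an ADME assay on A549 cells (Homo sapiens) for cytotoxicity, read by resazurin assay, with a stated time of 48 h; a higher number here means that more compound is tolerated, a lower number that less compound is tolerated. Compound 1 `CN(C)c1ccc(NC(=O)c2cc(Cl)ccc2O)c(Cl)c1` gives 85100 nM. Compound 2 `CCCN(CCC)c1ccc(NC(=O)c2cc(Cl)ccc2O)c(Cl)c1` gives 10700 nM, and compound 3 `O=C(Nc1ccc(NCc2ccc(F)cc2)cc1Cl)c1cc(Cl)ccc1O` gives 54400 nM. Among these three numbers compound 3 stands second highest. Its nearest neighbour is compound 1, and that difference, a 1.6-fold lower number from compound 1 to compound 3 (0.19 log units; within the scatter), lies within the scatter, so the two cannot be ordered. The furthest is compound 2, and the step of a 5.1-fold higher number from compound 2 to compound 3 (0.71 log units; beyond the scatter) is beyond the scatter, though modest in size.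

Compound 4 `O=C(Nc1ccc(NCc2cnccc2Cl)cc1Cl)c1cc(Cl)ccc1O` differs from compound 3 in one place: 4-chloropyridin-3-yl in place of 4-fluorophenyl on a saturated chain carbon bound to a nitrogen on an aromatic ring. The measured steps all change the group on the aromatic carbon of the core: an 8.0-fold lower number from compound 1 to compound 2 (0.90 log units; beyond the scatter), a 1.6-fold lower number from compound 1 to compound 3 (0.19 log units; within the scatter) and a 5.1-fold higher number from compound 2 to compound 3 (0.71 log units; beyond the scatter). Among the compounds with values here, none of them touches the ring carried by the saturated chain carbon, so no measured step speaks directly to the change from compound 3 to compound 4. Within the data shown here, the only exchanges of comparable kind, from compound 1 to compound 3, were within the scatter. On that basis no step beyond the scatter is expected in this assay , and the value of compound 4 is estimated at 45000 nM, with a range from 18000 nM to 110000 nM. This expectation corresponds to a step of a 1.2-fold lower number from compound 3 to compound 4 (0.08 log units; within the scatter).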

Compound 4, half-maximal cytotoxic concentration: 126000 nM
The estimate for compound 4 lay 2.8-fold (0.45 log units) below the measured number, and the stated range ends below it.
By their numbers in this assay, from the lowest: compound 2; then compounds 3, 1 and 4 (each within the scatter of the next, the first and the last beyond it).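

In this assay, the ring carried by the saturated chain carbon turns out to matter: 4-chloropyridin-3-yl in place of 4-fluorophenyl gives a 2.3-fold higher number from compound 3 to compound 4 (0.36 log units; beyond the scatter), a modest step but one beyond the scatter, whereas every earlier step changed the whole group on the aromatic carbon of the core and left this question untouched. With that ring in place, ((4-chloropyridin-3-yl)methyl)amino in place of dipropylamino gives a 12-fold higher number from compound 2 to compound 4 (1.07 log units; beyond the scatter), a large step, while in place of dimethylamino it gives a 1.5-fold higher number from compound 1 to compound 4 (0.17 log units; within the scatter), which lies within the scatter, so those two compounds cannot be ordered. Nothing at hand bears on what lies behind these steps.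

The exchange from compound 3 to compound 4 brings in the ring nitrogen and replaces fluorine with chlorine at once, so the compounds shown cannot divide the step between these two changes. A 4-chlorophenyl group or an unsubstituted pyridin-3-yl group on the same saturated chain carbon would separate them, and a longer chain between the ring and the nitrogen remains an open variation.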